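Imidazole in place of thiazolidinedione on a shared core

The source may hold more compounds than are shown below. What is called first, only, known or untested is meant among the compounds shown, and "the series" means these compounds.

Measured compounds in an ADME assay on L02 cells (Homo sapiens) for cytotoxicity, read by MTT assay, with a stated time of 48 h; a higher number here means a weaker inhibitor, a lower number a stronger inhibitor:
compound 1 `O=C1O[C@@H](CN2CCCCC2)CN1c1ccc(-n2cc(-c3ccccn3)cn2)c(F)c1` gives > 400 ug/mL, a limit of the assay rather than a number.
compound 2 `O=C1CCC(=O)N1C[C@H]1CN(c2ccc(-n3cc(-c4ccccn4)cn3)c(F)c2)C(=O)O1` gives > 400 ug/mL, a limit of the assay rather than a number.
compound 3 `O=C1CSC(=O)N1C[C@H]1CN(c2ccc(-n3cc(-c4ccccn4)cn3)c(F)c2)C(=O)O1` gives > 400 ug/mL, a limit of the assay rather than a number.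

Compound 3 therefore stands at a limit in this assay, and it shares that standing with the two other measured compounds, since the limit of > 400 ug/mL in this assay, at which 3 of the 3 values shown sit, describes every value recorded. The three measured steps, a step that the two limits leave unreadable from compound 1 to compound 2, a step that the two limits leave unreadable from compound 1 to compound 3 and a step that the two limits leave unreadable from compound 2 to compound 3, cannot be sized, as both ends of each sit at the limit.

Compound 4 `O=C1O[C@@H](Cn2ccnc2)CN1c1ccc(-n2cc(-c3ccccn3)cn2)c(F)c1` differs from compound 3 in one place: 1H-imidazol-1-yl in place of 2,4-dioxo-1,3-thiazolidin-3-yl on a saturated chain carbon bound to a saturated ring carbon. Within the data shown here, none of the measured steps is readable, so no direction and no size can be taken from them for this change. The step from compound 3 to compound 4 is therefore expected to be a number no higher from compound 3 to compound 4 (the limit leaves the size open), with the chance that a number rather than a limit appears kept open. Compound 4 is expected to give about 400 ug/mL in this assay. The estimate for compound 4 spans from 150 ug/mL to 800 ug/mL.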

Compound 4, half-maximal inhibitory concentration: 350 ug/mL
Beside the measured number, compound 4's estimate is 1.1-fold (0.06 log units) above it, within the range that was stated.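

In this assay compound 4, with 1H-imidazol-1-yl on the saturated chain carbon bound to a saturated ring carbon, is the only compound shown at this position that gives a number rather than a limit, so a group here can bring the read-out inside the range of the assay. The replacement reads as an at least 1.1-fold lower number from compound 3 to compound 4 (0.05 log units; that floor lies within the scatter) and as an at least 1.1-fold lower number from compound 2 to compound 4 (0.05 log units; that floor lies within the scatter) and as an at least 1.1-fold lower number from compound 1 to compound 4 (0.05 log units; that floor lies within the scatter) in the three comparisons; each is only a floor, so the true steps may be larger, but as printed none is shown to go beyond the usual scatter. The limit still describes most of the set, and the steps among compound 1, compound 2 and compound 3 cannot be read: the limit of > 400 ug/mL in this assay, at which 3 of the 4 values shown sit.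

As far as these compounds go, it stays open how far above the limit compound 1, compound 2 and compound 3 really lie, and so how large the change to 1H-imidazol-1-yl is. From the compounds shown here alone, it is also open whether a 1H-1,2,4-triazol-1-yl ring, a primary amine or a carboxylic acid at this position would give a number in this assay or stay at the limit.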